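Swapping a pyridine for a methoxyphenyl on the sulfonyl group

A few compounds are considered here, and "the series" means these few. Any claim that something is new, unique, unknown or untested is made for them only; others in the source may bear on it.

Measured compounds so far:
- Compound 1, `CC1CCN(C2CCN(S(=O)(=O)c3cn(C)cn3)CC2)CC1`: > 5000 nM
- Compound 2, `CC1CCN(C2CCN(S(=O)(=O)c3cccc(-c4ccccc4)c3)CC2)CC1`: 2 nM
- Compound 3, `CC1CCN(C2CCN(S(=O)(=O)c3cccnc3)CC2)CC1`: 2400 nM

Three compounds share a core and differ only in the aromatic group attached to the sulfonyl sulfur. In a functional assay on DLD-1 cells (Homo sapiens) for antiproliferative activity, read by CellTiter-Glo, with a stated time of 72 h (a higher number here means a weaker inhibitor, a lower number a stronger inhibitor), compound 1 gives > 5000 nM, which is a limit of the assay rather than a number (the limit of > 5000 nM in this assay, at which 1 of the 3 values shown sits). Compound 3 gives 2400 nM in this assay, the highest of the two real numbers shown. Compound 2 gives 2 nM in this assay, so between compound 2 and compound 3 the gap is very large, with compound 2 far the stronger.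

Among the measured compounds shown here, the one measured step that reaches compound 3 is an at least 2.0-fold lower number from compound 1 to compound 3 (0.31 log units; beyond the scatter). It shows that changing the aromatic group on the sulfonyl sulfur moves the number, though here only a lower bound on the step is known.

Compound 4, `COc1cccc(S(=O)(=O)N2CCC(N3CCC(C)CC3)CC2)c1`, has not yet been measured. Its change from compound 3 is 3-methoxyphenyl in place of pyridin-3-yl on a sulfonyl sulfur. This removes the ring nitrogen and brings in a carbon-only ring carrying a substituent, which is the direction compound 2 points toward with its value of 2 nM. A large drop in the number is therefore expected for compound 4, a 40-fold lower number from compound 3 to compound 4 (1.60 log units; beyond the scatter), though the methoxy group is much smaller than the phenyl of compound 2. Compound 4 is estimated at 60 nM in this assay, plausibly between 8 nM and 500 nM.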

Compound 4, half-maximal inhibitory concentration: > 5000 nM
Compound 4 was reported as a limit; the forecaster's own chance of this, stated with the estimate: 2%; at least 83-fold (1.92 log units) between middle value and limit.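

The result shows that a carbon-only ring on the sulfonyl sulfur does not by itself give a strong inhibitor in this assay: 3-methoxyphenyl in place of pyridin-3-yl brings an at least 2.0-fold higher number from compound 3 to compound 4 (0.31 log units; beyond the scatter), so losing the ring nitrogen gives no gain here. What separates the strong compound from the weak one is the group on the aromatic carbon, since methoxy in place of phenyl is linked to an at least 2500-fold higher number from compound 2 to compound 4 (3.39 log units; beyond the scatter), which ties the low number of compound 2 to its phenyl rather than to the carbon-only ring alone. Compound 4 gives a limit and not a number, and the step between compound 1 and compound 4 cannot be read, as both sit at the same limit: the limit of > 5000 nM in this assay, at which 2 of the 4 values shown sit.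

From the compounds shown here alone, how far compound 4 actually lies beyond that limit stays unknown, so the true size of its steps is open. Also open, going by these compounds, is whether a group other than phenyl on that aromatic carbon, such as a benzyl, a cyclohexyl or an amine, could keep a number near that of compound 2.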